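Permeability of a phenyl-for-phenoxy swap on the shared core

The source may report more compounds than this note shows. Statements on the series, on what has been measured and on what is new or still open speak of the compounds shown alone.

Compound 1 `COc1cccc(CNCCCNc2ccnc3cc(Oc4ccccc4)ccc23)c1O` is one of three measured compounds built on the same core. In an ADME assay for permeability, using PAMPA, with a stated time of 30 min, at pH 7.4 (a lower number here means that the compound crosses the layer more slowly, a higher number that the compound crosses the layer faster), compound 1 gives 317 10^-6 cm/s. Compound 2 `CC(C)(C)c1ccc(Oc2ccc3c(NCCCNCc4ccco4)ccnc3c2)cc1` gives 317 10^-6 cm/s in this assay, and compound 3 `c1ccc(Oc2ccc3c(NCCCNCc4ccco4)ccnc3c2)cc1` gives 317 10^-6 cm/s, so compound 1 stands level with both at the digits shown. The two measured steps were small: no change at the digits printed from compound 1 to compound 3 (within the scatter) and no change at the digits printed from compound 2 to compound 3 (within the scatter). Among the compounds with values here, neither touches the phenoxy group, so no measured step bears directly on the change now considered.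

Compound 4 `COc1cccc(CNCCCNc2ccnc3cc(-c4ccccc4)ccc23)c1O` differs from compound 1 in one place: phenyl in place of phenoxy on an aromatic carbon. Since every measured change on this core, whether at the saturated chain carbon or at an aromatic carbon, left this assay unchanged within the scatter, the author expects the same here, a step of no size beyond the scatter in either direction.

For compound 4 the estimated value in this assay is 317 10^-6 cm/s, with a range from 160 10^-6 cm/s to 630 10^-6 cm/s, meaning an expected step of no change at the digits printed from compound 1 to compound 4 (within the scatter).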

Compound 4, apparent permeability: 237 10^-6 cm/s
Compound 4: middle estimate off by 1.3-fold (0.13 log units), on the high side; the measured number falls inside the stated range.
By their numbers in this assay, from the lowest: compounds 4, 1, 2 and 3 (each within the scatter of the next).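

This step is the only one shown that replaces the phenoxy group itself, whereas the earlier steps left it in place. In this assay, phenyl in place of phenoxy gives a 1.3-fold lower number from compound 1 to compound 4 (0.13 log units; within the scatter), so on the core of compound 1 this aromatic carbon tolerates the loss of the phenoxy oxygen without a step beyond the scatter. No measurement shown offers an explanation for this result.

The compounds shown leave open whether a different group at this aromatic carbon, such as an amine or a carboxylic acid, would also stay within the scatter. They also leave open whether phenyl in place of phenoxy would give a similar step with the furan-2-yl group of compound 3 on the chain.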